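A few compounds are considered here, and "the series" means these few. Any claim that something is new, unique, unknown or untested is made for them only; others in the source may bear on it.

Of the compounds shown here, two have been measured so far, and compound 3 is the next to be placed.

Compound 1 `CC1=CC[C@@]2(O)[C@H](C)CC[C@@H](C(C)C)[C@@H]2C1=O` was tested in a functional assay on Bel-7402 cells (Homo sapiens) for cytotoxicity, read by MTT assay; a higher number here means a weaker inhibitor, a lower number a stronger inhibitor. In that assay compound 1 gives > 10 ug/mL, which is a limit of the assay and not a number. Compound 2 `CC1=CC[C@]2(O)[C@@H]([C@@H]1O)[C@H](C(C)C)CC[C@H]2C` was tested in the same way. In this assay compound 2 gives > 10 ug/mL, again a limit rather than a number. Both results shown sit at the same limit (the limit of > 10 ug/mL in this assay, at which 2 of the 2 values shown sit), so compound 2 stands at that limit, and no order between the two measured compounds can be read.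

Compound 3 `CC1=CC[C@]2(O)[C@@H]([C@H]1O)[C@H](C(C)C)CC[C@H]2C` is not yet measured. It differs from compound 2 as follows: the two compounds have the same atoms and bonds and differ only in configuration as drawn: 1 of 5 stereo elements differ; a stereocentre at a saturated ring carbon is drawn S in compound 2 and R in compound 3. No step between two measured compounds is available to judge what a change in configuration does in this series, and nothing shown links potency to configuration. In this assay the expected step is a step that the limit leaves unreadable from compound 2 to compound 3, that is, nothing beyond the scatter. Compound 3 is therefore estimated at 15 ug/mL, within a range of 7 ug/mL to 40 ug/mL, and is most likely to be reported again only as a limit.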

Compound 3, half-maximal inhibitory concentration: > 10 ug/mL
Compound 3 ended at the assay's limit (the forecaster's own chance of this, stated with the estimate: 80%); the middle value is on the limit's open side.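

No step can be read between compound 2 and compound 3, since the result for compound 3 is again a limit and not a number, and all results shown sit at that limit: the limit of > 10 ug/mL in this assay, at which 3 of the 3 values shown sit.

The compounds shown leave open whether configuration at this saturated ring carbon affects potency in this assay, and where any of the three compounds truly lies.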